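The compounds below may be only part of what the source reports. "The series", "measured", "known", "first", "only" and "open" are said of these compounds alone.

In a functional assay on K562 cells (Homo sapiens) for cytotoxicity, read by MTT assay (on this read-out lower numbers stand for stronger inhibition and higher numbers for weaker inhibition), compound 1 `COc1ccc(/C=C/C(=O)c2ccc(OC)c3c2OC(C)(C)C=C3)cc1O`, with a hydrogen on the aromatic oxygen, gives 630 nM. Replacing that hydrogen with butylcarbonyl gives compound 2 `CCCCC(=O)Oc1cc(/C=C/C(=O)c2ccc(OC)c3c2OC(C)(C)C=C3)ccc1OC` at 240 nM, and replacing it with cyclopropylcarbonyl gives compound 3 `COc1ccc(/C=C/C(=O)c2ccc(OC)c3c2OC(C)(C)C=C3)cc1OC(=O)C1CC1` at 410 nM. The number for compound 3 falls inside the span of the other two and lies within the scatter of each, as a 1.5-fold lower number from compound 1 to compound 3 (0.19 log units; within the scatter) and a 1.7-fold higher number from compound 2 to compound 3 (0.23 log units; within the scatter) show. Only the outer pair stands clear of the scatter, with a 2.6-fold lower number from compound 1 to compound 2 (0.42 log units; beyond the scatter).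

Compound 4 `COc1cccc(C(=O)Oc2cc(/C=C/C(=O)c3ccc(OC)c4c3OC(C)(C)C=C4)ccc2OC)c1` keeps the shared core and changes only the group on the carbonyl: 3-methoxyphenyl in place of cyclopropyl on a carbonyl carbon. Here, 3-methoxyphenyl stands in place of cyclopropyl on a carbonyl carbon. Among the compounds with values here, the closest precedent is the exchange of butyl for cyclopropyl at the same carbon, a 1.7-fold higher number from compound 2 to compound 3 (0.23 log units; within the scatter), which stays within the scatter. The two steps from compound 1 concern adding the acyl group, not exchanging it, so they bear on this change less directly. Within the data shown here, no compound with an aromatic ring at this carbon has been measured, so the direction remains open and no shift beyond the scatter is expected. The expected change is a 1.2-fold lower number from compound 3 to compound 4 (0.07 log units; within the scatter). For compound 4, the estimated value is 350 nM, with an expected range from 130 nM to 900 nM.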

Compound 4, half-maximal inhibitory concentration: 790 nM
The estimate for compound 4 lay 2.3-fold (0.35 log units) below the measured number, and the stated range covers the measured number.
By their numbers in this assay, from the lowest: compounds 2, 3, 1 and 4 (each within the scatter of the next, the first and the last beyond it).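

In this assay, the exchange of butyl for 3-methoxyphenyl on the carbonyl carbon stands clear of the scatter (a 3.3-fold higher number from compound 2 to compound 4 (0.52 log units; beyond the scatter)), which the exchange of butyl for cyclopropyl did not do. The exchange of cyclopropyl for 3-methoxyphenyl stays within the scatter (a 1.9-fold higher number from compound 3 to compound 4 (0.28 log units; within the scatter)), and so does the step from the free hydrogen on the oxygen to the (3-methoxyphenyl)carbonyl group (a 1.3-fold higher number from compound 1 to compound 4 (0.10 log units; within the scatter)), so compound 4 cannot be told apart from either compound 3 or compound 1. Acylation at this oxygen therefore does not by itself give a number clear of compound 1: among the three acyl groups, only the one in compound 2 does so, while compound 3 and compound 4 go against any such general rule.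

The data shown offer no explanation for these differences. On these data alone, it remains open whether a shorter or longer chain, such as propyl or hexyl, would match butyl on the carbonyl carbon, and whether plain phenyl would read differently from 3-methoxyphenyl.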